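A few compounds are considered here, and "the series" means these few. Any claim that something is new, unique, unknown or untested is made for them only; others in the source may bear on it.

Working notes on the series. In a functional assay on HepG2 cells (Homo sapiens) for antiproliferative activity, read by spectrophotometry, with a stated time of 2 days (on this read-out higher numbers stand for weaker inhibition of growth and lower numbers for stronger inhibition of growth), compound 1 (`Cc1ccc(Nc2ncc(C(F)(F)F)c(N3Cc4cccc(N(C)S(C)(=O)=O)c4C3)n2)cc1C`) gives > 30000 nM as a limit of the assay, not a number. For the measured compounds named here, compound 2 (`CN(c1cccc2c1CN(c1nc(Nc3ccc(Nc4ccccc4)cc3)ncc1C(F)(F)F)C2)S(C)(=O)=O`) gives 8600 nM in this assay and holds the only number so far.

Compound 3 (`CN(c1cccc2c1CN(c1nc(Nc3ccc(C(F)(F)F)cc3)ncc1C(F)(F)F)C2)S(C)(=O)=O`) carries trifluoromethyl in place of anilino on an aromatic carbon, para to a large group (trifluoromethyl in place of anilino on an aromatic carbon). Going by the values given here, no measured step isolates this change, so any expectation rests on the two readings alone. Compound 1, which has no anilino, stays at the limit of > 30000 nM in this assay and so a moderate move towards weaker inhibition of growth is expected. The estimated move is a 2.6-fold higher number from compound 2 to compound 3 (0.41 log units; beyond the scatter) and it may end at the limit. For compound 3 the estimate is 22000 nM with an expected range from 9000 nM to 55000 nM in this assay for now.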

Compound 3, concentration for 50% growth inhibition: > 30000 nM
Compound 3: only a limit was reported (the forecaster's own chance of this, stated with the estimate: 45%); at least 1.3-fold (0.13 log units) between middle value and limit.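

In this assay, trifluoromethyl in place of anilino on this aromatic carbon, para to a large group, gives an at least 3.4-fold higher number from compound 2 to compound 3 (0.54 log units; beyond the scatter). Among the compounds shown, a number is reached only with anilino in compound 2, whereas compound 1 and compound 3, which lack it, give only limits, and the step between those two limits cannot be read. The loss on leaving anilino therefore has a lower bound but no upper one, and the series offers little range for comparison at this end: the limit of > 30000 nM in this assay, at which 2 of the 3 values shown sit.

Still open, going by these compounds, is how far past its limit compound 3 lies, and whether a small amine or a methoxy group at this place would keep the reading of compound 2. The compounds shown also do not separate the ring of anilino from its nitrogen, a question that a phenoxy or benzyl group could address.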